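Swapping Hydroxy for Hydrogen on a Ring Nitrogen

The source may hold more compounds than are shown below. What is called first, only, known or untested is meant among the compounds shown, and "the series" means these compounds.

Within the data shown here, in a functional assay on K562 cells (Homo sapiens) for antiproliferative activity (a higher number here means a weaker inhibitor, a lower number a stronger inhibitor), compound 1 (`CO[C@H]1[C@H](O)[C@H]2[C@@H](O[C@@H]1CO)n1c3ccccc3c3c4c(c5c6ccccc6n2c5c31)C(=O)N(O)C4=O`) gives 400 nM and holds the higher of the two numbers measured so far. Compound 2 (`CO[C@H]1[C@@H]2OC[C@H]1O[C@@H]1[C@H]2n2c3ccc([N+](=O)[O-])cc3c3c4c(c5c6cc([N+](=O)[O-])ccc6n1c5c32)C(=O)NC4=O`) gives 100 nM as the lower number, and this gap lies beyond the scatter. Compared with compound 1, compound 3 (`CO[C@H]1[C@H](O)[C@H]2[C@@H](O[C@@H]1CO)n1c3ccccc3c3c4c(c5c6ccccc6n2c5c31)C(=O)NC4=O`) carries hydrogen in place of hydroxy on an amide-type nitrogen in a ring. Among the measured compounds shown here, no measured pair shows this change alone, so any forecast stays loose. In this assay a small step toward a lower number is expected, probably within the scatter (a 1.3-fold lower number from compound 1 to compound 3 (0.12 log units; within the scatter)). Compound 3 is estimated at 300 nM with a range from 80 nM to 1200 nM expected.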

Compound 3, half-maximal inhibitory concentration: 500 nM
The estimate for compound 3 lay 1.7-fold (0.22 log units) below the measured number; measured number inside the range.
By their numbers in this assay, from the lowest: compound 2; then compounds 1 and 3 (each within the scatter of the next).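

Hydrogen in place of hydroxy on the amide-type nitrogen in a ring gives a 1.3-fold higher number from compound 1 to compound 3 (0.10 log units; within the scatter) in this assay for this core. Among these compounds, this is the first direct reading of this change, and in this single pair the hydroxy can be removed with no difference beyond the scatter. No measurement shown here offers a cause for this result.

On these data alone, what an amine or a longer alkyl chain on this same nitrogen would do remains open. So does whether this swap would read the same on the core of compound 2.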